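A few compounds are considered here, and "the series" means these few. Any claim that something is new, unique, unknown or untested is made for them only; others in the source may bear on it.

Within the data shown here, in a functional assay on BT-474 cells (Homo sapiens) for inhibition, read by MTT assay, with a stated time of 5 days (a lower number here means a stronger inhibitor, a higher number a weaker inhibitor), compound 1 `Cc1cc(Nc2nc(NCc3ccccc3Br)nc3[nH]ncc23)n[nH]1` gives 10100 nM and compound 2 `Cc1cc(Nc2nc(NCc3cccc(Cl)c3)nc3[nH]ncc23)n[nH]1` gives 12900 nM, so compound 2 stands within the scatter of the only other measured value. Compound 3 `Cc1cc(Nc2nc(NCc3ccc(Cl)cc3)nc3[nH]ncc23)n[nH]1` differs from compound 2 by 4-chlorophenyl in place of 3-chlorophenyl on a saturated chain carbon bound to a nitrogen on an aromatic ring. Among the measured compounds shown here, the one measured step at this place, a 1.3-fold higher number from compound 1 to compound 2 (0.11 log units; within the scatter), lies within the scatter, so no step beyond the scatter is expected in this assay. The estimated 1.2-fold lower number from compound 2 to compound 3 (0.07 log units; within the scatter) also stays within the scatter. Compound 3 is expected at 11000 nM, with an estimated range of 5000 nM to 25000 nM.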

Compound 3, half-maximal inhibitory concentration: 11700 nM
Beside the measured number, compound 3's estimate is 1.1-fold (0.03 log units) below it, within the range that was stated.
By their numbers in this assay, from the lowest: compounds 1, 3 and 2 (each within the scatter of the next).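

In this assay the chlorine's ring position gives no readable step: 4-chlorophenyl in place of 3-chlorophenyl gives a 1.1-fold lower number from compound 2 to compound 3 (0.04 log units; within the scatter) and 4-chlorophenyl in place of 2-bromophenyl gives a 1.2-fold higher number from compound 1 to compound 3 (0.06 log units; within the scatter) as well. On a saturated chain carbon bound to a nitrogen on an aromatic ring, compounds 1, 2 and 3 therefore cannot be told apart, whichever of the three groups is present. No evidence on a cause accompanies this result. Open, going by these compounds, is whether an unsubstituted phenyl, a carboxylic acid or an amine at this place would give a step beyond the scatter.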